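The source may report more compounds than this note shows. Statements on the series, on what has been measured and on what is new or still open speak of the compounds shown alone.

In a functional assay on A2780 cells (Homo sapiens) for antiproliferative activity, read by MTT assay, with a stated time of 48 h (on this read-out lower numbers stand for stronger inhibition and higher numbers for weaker inhibition), compound 2 (`C=C(c1ccc(OC)cc1NC(=O)CO)c1ccc(OC)c2c1C=CC(C)(C)O2`) gives 280 nM and lies within the scatter of compound 3 (`C=C(c1ccc(OC)cc1NC(=O)CNC)c1ccc(OC)c2c1OC(C)(C)C=C2`) at 210 nM on this read-out. Compound 1 (`CNCC(=O)Nc1cc(OC)ccc1C(=O)c1ccc(OC)c2c1OC(C)(C)C=C2`) gives 620 nM and is weaker than compound 2 by a gap beyond the scatter. Compound 4 (`C=C(c1ccc(OC)cc1NC(=O)CN(C)C)c1ccc(OC)c2c1C=CC(C)(C)O2`) departs from compound 2 in one place (dimethylamino in place of hydroxy on a saturated chain carbon bound to a carbonyl carbon) with dimethylamino in place of hydroxy on a saturated chain carbon bound to a carbonyl carbon. For the measured compounds named here, no measured step isolates this change. Compound 3 carries an amine on that chain on a differently arranged core, and its value (210 nM) stays within the scatter of compound 2, so no step beyond the scatter is expected in this assay. The expected step of a 1.1-fold lower number from compound 2 to compound 4 (0.05 log units; within the scatter) is an estimate only. For compound 4 the estimated value is 250 nM with an expected range of 100 nM to 650 nM here.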

Compound 4, half-maximal inhibitory concentration: 670 nM
Estimate against measurement, compound 4: 2.7-fold (0.43 log units) below; the whole stated range lies below it.
By their numbers in this assay, from the lowest: compounds 3 and 2 (each within the scatter of the next); then compounds 1 and 4 (each within the scatter of the next).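

In this assay, dimethylamino in place of hydroxy on a saturated chain carbon bound to a carbonyl carbon gives a 2.4-fold higher number from compound 2 to compound 4 (0.38 log units; beyond the scatter), the first step read at this position. The number here therefore depends on the group at this place, and this change moves it toward weaker inhibition. No measurement on hand accounts for this step.

Going by these compounds, whether the shift follows from losing hydroxy or from gaining dimethylamino stays open. A primary amine, a carboxylic acid or a longer chain at this place on the same core would help separate the two.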